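Lengthening the nitrile chain from compound 3 to compound 4

The source may report more compounds than this note shows. Statements on the series, on what has been measured and on what is new or still open speak of the compounds shown alone.

compound 1 `CCn1nc(C(=O)N[C@H]2COc3ccccc3N(C)C2=S)nc1Cc1ccccc1` gives 17 nM 
compound 2 `CC(C)CCn1nc(C(=O)N[C@H]2COc3ccccc3N(C)C2=S)nc1Cc1ccccc1` gives 3640 nM 
compound 3 `CN1C(=S)[C@@H](NC(=O)c2nc(Cc3ccccc3)n(CCCC#N)n2)COc2ccccc21` gives 2400 nM 

These three values all come from a functional assay on HT-29 cells (Homo sapiens) for inhibition, read by luminescence and CellTiter-Glo, with a stated time of 24 h (a higher number here means that more compound is needed for the effect, a lower number that less compound is needed), and the compounds share one core. Compound 3, at 2400 nM, sits with compound 2 at the high end of these numbers. The step of a 1.5-fold lower number from compound 2 to compound 3 (0.18 log units; within the scatter) lies within the scatter, whereas the step of a 140-fold higher number from compound 1 to compound 3 (2.15 log units; beyond the scatter) is large, as is the step of a 210-fold higher number from compound 1 to compound 2 (2.33 log units; beyond the scatter) on swapping in isopropyl.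

Compound 4 `CN1C(=S)[C@@H](NC(=O)c2nc(Cc3ccccc3)n(CCCCC#N)n2)COc2ccccc21` carries 4-cyanobutyl where compound 3 carries 3-cyanopropyl, a change of cyanomethyl in place of cyano on a saturated chain carbon, three bonds along the chain from an aromatic nitrogen that puts cyanomethyl in place of cyano on a saturated chain carbon, three bonds along the chain from an aromatic nitrogen.

Among the measured compounds shown here, no measured step matches this change. The nearest ones act two bonds along the chain, and both large steps there end at similar values. They give no sign that extending the chain further would return the number towards that of compound 1, though three compounds show little. A step beyond the scatter is therefore not expected in this assay, with any drift more likely upward. The expected step is a 1.3-fold higher number from compound 3 to compound 4 (0.10 log units; within the scatter) and remains an estimate. For compound 4 the estimated value is 3000 nM, within an expected range of 800 nM to 11000 nM.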

Compound 4, half-maximal effective concentration: 2680 nM
Beside the measured number, compound 4's estimate is 1.1-fold (0.05 log units) above it; low and high end bracket the measured number.
By their numbers in this assay, from the lowest: compound 1; then compounds 3, 4 and 2 (each within the scatter of the next).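

In this assay, the further extension from 3-cyanopropyl to 4-cyanobutyl leaves the number where it stood (a result of a 1.1-fold higher number from compound 3 to compound 4 (0.05 log units; within the scatter)), so cyanomethyl in place of cyano, three bonds along the chain from an aromatic nitrogen, has no effect that can be told from the scatter. The 4-cyanobutyl chain also cannot be separated from the isopropyl-ended chain of compound 2 (with a 1.4-fold lower number from compound 2 to compound 4 (0.13 log units; within the scatter)), while the gap to compound 1 remains large (with a 160-fold higher number from compound 1 to compound 4 (2.20 log units; beyond the scatter)), so compounds 2, 3 and 4 form one group of similar numbers and compound 1 alone stands apart from it. No supporting measurement is available to explain why these longer chains give such similar numbers or why compound 1 differs from them.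

The compounds shown leave open how the number behaves with a chain lying in length between that of compound 1 and those of the other three, such as a propyl or a cyanomethyl chain. They also leave open whether a chain of this length ending in an amine or a carboxylic acid, in place of the nitrile, would stay with compounds 3 and 4 or come closer to compound 1.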